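The source may hold more compounds than are shown below. What is called first, only, known or untested is meant among the compounds shown, and "the series" means these compounds.

Compound 1 `CC(C)c1n[nH]c2c(NCc3ccc(-c4ccccn4)cc3)nc(SCC(O)CN3CCNCC3)nc12`: 332 nM
Compound 2 `C=CCSc1nc(NCc2ccc(-c3ccccn3)cc2)c2[nH]nc(C(C)C)c2n1`: 1010 nM
Compound 3 `COCSc1nc(NCc2ccc(-c3ccccn3)cc2)c2[nH]nc(C(C)C)c2n1`: 340 nM

These values come from a functional assay on HT cells (Homo sapiens) for antiproliferative activity, read by fluorescence, with a stated time of 72 h; a lower number here means a stronger inhibitor of growth, a higher number a weaker inhibitor of growth. Compound 3 matches compound 1, with a 1.0-fold higher number from compound 1 to compound 3 (0.01 log units; within the scatter), and clearly differs from compound 2, with a 3.0-fold lower number from compound 2 to compound 3 (0.47 log units; beyond the scatter).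

Compound 4 `CCC(CO)Sc1nc(NCc2ccc(-c3ccccn3)cc2)c2[nH]nc(C(C)C)c2n1` changes the group on the sulfur, with 1-(hydroxymethyl)propyl in place of methoxymethyl on a sulfur.

All three measured steps also alter the chain on that sulfur. Besides the two above, there is a 3.0-fold higher number from compound 1 to compound 2 (0.48 log units; beyond the scatter). None exceeds a modest size, so only a small change is expected here, probably within the scatter. The estimated step is a 1.3-fold lower number from compound 3 to compound 4 (0.10 log units; within the scatter). For compound 4 the expected value is 270 nM, with an estimated range of 110 nM to 700 nM.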

Compound 4, concentration for 50% growth inhibition: 255 nM
Beside the measured number, compound 4's estimate is 1.1-fold (0.02 log units) above it, and the stated range covers the measured number.
By their numbers in this assay, from the lowest: compounds 4, 1 and 3 (each within the scatter of the next); then compound 2.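

In this assay, 1-(hydroxymethyl)propyl on the sulfur, which brings a hydrogen-bond donor that methoxymethyl lacks, reads level with methoxymethyl (a 1.3-fold lower number from compound 3 to compound 4 (0.12 log units; within the scatter)) and with the 2-hydroxy-3-(piperazin-1-yl)propyl chain (a 1.3-fold lower number from compound 1 to compound 4 (0.11 log units; within the scatter)). Allyl alone stands apart (a 4.0-fold lower number from compound 2 to compound 4 (0.60 log units; beyond the scatter)), so among these four compounds only compound 2 breaks the level pattern at this sulfur. As far as these compounds go, whether a carboxylic acid or a phenyl ring on this chain would hold that level stays open. Nothing available explains why these chains read alike or why allyl differs.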